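Widening the Terminal Amine Ring of Compound 2

The source may hold more compounds than are shown below. What is called first, only, known or untested is meant among the compounds shown, and "the series" means these compounds.

Compound 2 `COc1cc2c(Oc3ccc(NC(=O)c4nn(-c5ccc([N+](=O)[O-])cc5)c(=O)c5ccccc45)cc3F)ccnc2cc1OCCCN1CCCC1` gives 1760 nM in a functional assay on HT-29 cells (Homo sapiens) for cytotoxicity, read by MTT assay, with a stated time of 72 h (on this read-out higher numbers stand for weaker inhibition and lower numbers for stronger inhibition), which places it second highest of the three numbers measured. Compound 1 `COc1cc2c(Oc3ccc(NC(=O)c4nn(-c5ccccc5F)c(=O)c5ccccc45)cc3F)ccnc2cc1OCCCN1CCCC1` gives 400 nM, and the step of a 4.4-fold higher number from compound 1 to compound 2 (0.64 log units; beyond the scatter) lies beyond the scatter, as does a 5.9-fold higher number from compound 1 to compound 3 (0.77 log units; beyond the scatter). Compound 3 `COc1ccc(-n2nc(C(=O)Nc3ccc(Oc4ccnc5cc(OCCCN6CCCC6)c(OC)cc45)c(F)c3)c3ccccc3c2=O)cc1` gives 2360 nM; the step of a 1.3-fold higher number from compound 2 to compound 3 (0.13 log units; within the scatter) lies within the scatter, so compound 2 and compound 3 cannot be ordered against each other. Compound 4 `COc1cc2c(Oc3ccc(NC(=O)c4nn(-c5ccc([N+](=O)[O-])cc5)c(=O)c5ccccc45)cc3F)ccnc2cc1OCCCN1CCCCC1` differs from compound 2 by piperidin-1-yl in place of pyrrolidin-1-yl on a saturated chain carbon, three bonds along the chain from an oxygen on an aromatic ring. None of the three measured steps touches this part of the molecule: each of them alters either the group on the aromatic nitrogen or the substituent on an aromatic carbon, while the chain amine stays the same throughout. Nothing in the data therefore speaks for a shift in this assay in either direction, and the expected step of a 1.0-fold higher number from compound 2 to compound 4 (0.01 log units; within the scatter) is one within the scatter. Compound 4 is estimated at 1800 nM, with a range from 800 nM to 4000 nM.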

Compound 4, half-maximal inhibitory concentration: 2170 nM
Compound 4: middle estimate off by 1.2-fold (0.08 log units), on the low side; the range from low to high includes it.
By their numbers in this assay, from the lowest: compound 1; then compounds 2, 4 and 3 (each within the scatter of the next).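

In this assay, exchanging pyrrolidin-1-yl for piperidin-1-yl at the end of the chain gives a 1.2-fold higher number from compound 2 to compound 4 (0.09 log units; within the scatter), so with the 4-nitrophenyl group on the aromatic nitrogen, this widening of the amine ring leaves no difference that can be told from the scatter. Among the compounds shown here, the earlier steps all left the chain amine in place, so this is the first reading at this position, and it shows that the number does not depend measurably on which of these two rings ends the 3-(pyrrolidin-1-yl)propyl or 3-(piperidin-1-yl)propyl chain. No measured property bears on this result, and no reason for it can be offered.

From the compounds shown here alone, it remains open whether a morpholine ring or an open dimethylamino group at the chain end would behave the same way, or whether a shorter or longer chain would. Going by these compounds, it is also open whether piperidin-1-yl would leave the number as little changed with 2-fluorophenyl on the aromatic nitrogen, as in compound 1.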